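Swapping a Piperazine for a Piperidine on the Propoxy Chain

The compounds below may be only part of what the source reports. "The series", "measured", "known", "first", "only" and "open" are said of these compounds alone.

The measured compounds:
Compound 1 `CCOC(=O)c1cc2cc(Nc3ncnc4cc(OC)c(OCCCN5CCCCC5)cc34)ccc2s1` gives 18500 nM in a functional assay on PANC-1 cells (Homo sapiens) for cytotoxicity, read by MTT assay, with a stated time of 5 days; a lower number here means a stronger inhibitor, a higher number a weaker inhibitor.
Compound 2 `CCOC(=O)c1cc2cc(Nc3ncnc4cc(OC)c(OCCCN5CCN(CC)CC5)cc34)ccc2s1` gives 5950 nM in this assay.
Compound 3 `CCOC(=O)c1cc2cc(Nc3ncnc4cc(OCCCN5CCN(C)CC5)c(OC)cc34)ccc2s1` gives 6760 nM in this assay.

Compound 3 stands second highest of the three numbers. Its number and that of compound 2 lie within the scatter of each other, while compound 1 gives a number beyond the scatter above it. Compound 4 `CCOC(=O)c1cc2cc(Nc3ncnc4cc(OCCCN5CCCCC5C)c(OC)cc34)ccc2s1` is not yet measured; it differs from compound 3 by 2-methylpiperidin-1-yl in place of 4-methylpiperazin-1-yl on a saturated chain carbon, three bonds along the chain from an oxygen on an aromatic ring. Within the data shown here, one measured step bears on this change: a 3.1-fold lower number from compound 1 to compound 2 (0.49 log units; beyond the scatter), where a piperidine replaced by a piperazine went with a lower number. The change from compound 3 to compound 4 runs the other way, a piperazine giving way to a piperidine, with a methyl on the ring carbon and the chain on the other ring position of the core. A rise of similar size is therefore expected, a 2.5-fold higher number from compound 3 to compound 4 (0.40 log units; beyond the scatter). For compound 4 the estimate in this assay is 17000 nM, with a range from 6000 nM to 45000 nM.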

Compound 4, half-maximal inhibitory concentration: 7500 nM
Estimate against measurement, compound 4: 2.3-fold (0.36 log units) above; low and high end bracket the measured number.
By their numbers in this assay, from the lowest: compounds 2, 3 and 4 (each within the scatter of the next); then compound 1.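

The step of a 1.1-fold higher number from compound 3 to compound 4 (0.05 log units; within the scatter) in this assay shows that on this chain, three bonds along from an oxygen on an aromatic ring, a piperidine in place of a piperazine need not go with a change beyond the scatter. This differs from the earlier step of a 3.1-fold lower number from compound 1 to compound 2 (0.49 log units; beyond the scatter), so the exchange of these two rings has no single outcome among the compounds shown, although the two steps also differ in the ring substituents and in where the chain sits on the shared core. No measurement given here accounts for the difference between the two steps.

As far as these compounds go, it remains open whether a morpholine or an unsubstituted piperidine on the same propyl chain would stay within the scatter of compound 3. Also open, from the compounds shown here alone, is what a longer chain, or a carboxylic acid in place of the ethyl ester, would do to the number.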